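Dimethylthiophene on a second core: an expected shift

The compounds below may be only part of what the source reports. "The series", "measured", "known", "first", "only" and "open" are said of these compounds alone.

Of the compounds shown here, three have been measured in a functional assay on cells (Cancer cell lines, Homo sapiens) for inhibition; on this read-out lower numbers stand for stronger inhibition of growth and higher numbers for weaker inhibition of growth. Compound 1 `N=C(N)N/N=C/c1c(-c2ccsc2)nc2sccn12` gives 14800 nM. In this assay compound 2 `Cc1cc(-c2nc3sccn3c2/C=N/NC(=N)N)c(C)s1` gives 17800 nM. Compound 2 differs from compound 1 by 2,5-dimethylthiophen-3-yl in place of thiophen-3-yl on an aromatic carbon and the step is a 1.2-fold higher number from compound 1 to compound 2 (0.08 log units; within the scatter). Compound 3 `N=C(N)N/N=C/c1c(-c2ccsc2)nc2n1CCS2` carries a different core; how its core differs from that of compound 1 is not broken down here. In this assay compound 3 gives 28200 nM, and its gaps to compound 1 and compound 2 both lie within the usual scatter, so no order among the three can be read from them.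

Compound 4 `Cc1cc(-c2nc3n(c2/C=N/NC(=N)N)CCS3)c(C)s1` has not yet been measured. It differs from compound 3 by 2,5-dimethylthiophen-3-yl in place of thiophen-3-yl on an aromatic carbon, the same kind of change as that from compound 1 to compound 2; around the place, the change in compound 3 is also two ring bonds from two ring atoms that each bear a fused ring. Because the earlier step was a 1.2-fold higher number from compound 1 to compound 2 (0.08 log units; within the scatter), the expected step in this assay is a 1.2-fold higher number from compound 3 to compound 4 (0.07 log units; within the scatter). Compound 4 is therefore estimated at about 33000 nM, with an expected range from 15000 nM to 75000 nM.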

Compound 4, concentration for 50% growth inhibition: 17400 nM
Beside the measured number, compound 4's estimate is 1.9-fold (0.28 log units) above it; the range from low to high includes it.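

In this assay, 2,5-dimethylthiophen-3-yl in place of thiophen-3-yl on the core of compound 3 gives a 1.6-fold lower number from compound 3 to compound 4 (0.21 log units; within the scatter), so this step, like the earlier one, cannot be told apart from the ordinary spread of repeated measurements. Set side by side, the two steps do not differ, so as far as these numbers can tell, the change behaves alike on both cores: the same change on two cores in this assay, a 1.2-fold higher number (0.08 log units; within the scatter) from compound 1 to compound 2 and a 1.6-fold lower number (0.21 log units; within the scatter) from compound 3 to compound 4, 1.9-fold (0.29 log units) apart, within the scatter of two such steps. This does not show that the change has a real effect that carries from one core to the other, as neither step stands clear of the scatter, and two pairs of compounds say nothing about any further core.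

The compounds shown leave open whether a different group on this aromatic carbon, such as an amine, a carboxylic acid or a longer chain, would shift the number beyond the scatter on either core. They also leave open what happens when the group of 6 heavy atoms, the same in all four compounds, is replaced.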